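The source may report more compounds than this note shows. Statements on the series, on what has been measured and on what is new or still open speak of the compounds shown alone.

Measured compounds:
Compound 1: `CCCCCCCCCCO[C@H]1C=C(COC(C)=O)C(=O)[C@@H]2O[C@@](C)(OC)[C@](C)(OC)O[C@@H]12` — 33100 nM in an assay on isolated protein for inhibition of glutathione S-transferase A2 (Homo sapiens), read by spectrophotometry, with a stated time of 3 min; a higher number here means a weaker inhibitor, a lower number a stronger inhibitor
Compound 2: `CO[C@]1(C)O[C@H]2[C@@H](O)C=C(COC(C)=O)C(=O)[C@@H]2O[C@@]1(C)OC` — "not determined" (no result reported) in this assay

Compound 2 stands nowhere on the numbers: in this assay no half-maximal inhibitory concentration was reported for it, so it has no value to compare with. Going by the values given here, the only measured anchor is compound 1, which in this assay gives 33100 nM, a weak inhibition. In compound 1 the oxygen on a saturated carbon bears a chain rather than a hydrogen.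

Compound 3, with the structure `CO[C@]1(C)O[C@H]2[C@@H](OC/C=C(\C)CCC=C(C)C)C=C(COC(C)=O)C(=O)[C@@H]2O[C@@]1(C)OC`, differs from compound 2 by 3,7-dimethylocta-2,6-dien-1-yl in place of hydrogen on an oxygen on a saturated carbon. Since compound 2 has no number, the step from compound 2 to compound 3 in this assay cannot be given a size or a direction; it can only be said that compound 3, like compound 1, carries a chain on that oxygen.

Compound 3 is therefore expected to land near compound 1 rather than anywhere else, because compound 1 gives 33100 nM. In this assay compound 3 is estimated at 30000 nM, with an expected range from 8000 nM to 110000 nM.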

Compound 3, half-maximal inhibitory concentration: 179000 nM
Compound 3: middle estimate off by 6.0-fold (0.78 log units), on the low side; the measured number lies above the stated range.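

In this assay the kind of chain on this oxygen makes a measurable difference: with 2,6-dimethylhepta-1,5-dien-1-yl in place of nonyl, on a saturated chain carbon bound to an oxygen on a saturated carbon, the step is a 5.4-fold higher number from compound 1 to compound 3 (0.73 log units; beyond the scatter) and marks compound 3 as the weaker inhibitor of the pair. The two chains are therefore not interchangeable at this place, although the step is modest and it rests on this single pair of compounds. No measurement shown here explains the step.

As far as these compounds go, compound 2 has no number, so the steps from its free hydroxy to either chain cannot be read, and it remains unknown whether adding a chain at this oxygen strengthens or weakens inhibition at all. Going by these compounds alone, the single step also changes branching and double bonds together, so a saturated 3,7-dimethyloctyl chain would be needed to separate the two, while a benzyl group or a chain ending in an amine would show how far this place accepts other kinds of group.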